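Two Chlorines to Two Methyls on the Pendant Phenyl Ring

The source may report more compounds than this note shows. Statements on the series, on what has been measured and on what is new or still open speak of the compounds shown alone.

Measured so far:
Compound 1, `CCCS(=O)(=O)Nc1ccc(F)c(C(=O)c2n[nH]c3ncc(-c4ccc(C)cc4)cc23)c1F`, in an assay for binding affinity to dual specificity mitogen-activated protein kinase kinase 4 (Homo sapiens), read by KINOMEscan, tested at 100 nM (a higher number here means a weaker effect of the compound at the concentration tested, a lower number a stronger effect), gives 5.4%.
Compound 2, `CCCS(=O)(=O)Nc1ccc(F)c(C(=O)c2n[nH]c3ncc(-c4ccc(Cl)c(Cl)c4)cc23)c1F`, in this assay gives 45%.

For the measured compounds named here, compound 2 stands at the higher of the two numbers, which here means the weaker effect; its only neighbour is compound 1, and the step of a number 39.6 percentage points higher from compound 1 to compound 2 (beyond the scatter) lies well beyond the scatter.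

Compound 3, `CCCS(=O)(=O)Nc1ccc(F)c(C(=O)c2n[nH]c3ncc(-c4ccc(C)c(C)c4)cc23)c1F`, has not yet been measured. It differs from compound 2 in one place: 3,4-dimethylphenyl in place of 3,4-dichlorophenyl on an aromatic carbon.

Going by the values given here, only one measured step bears on this change: a number 39.6 percentage points higher from compound 1 to compound 2 (beyond the scatter), which replaced 4-methylphenyl with 3,4-dichlorophenyl and was large. That step changed two things at once, the number of substituents and their kind, so it cannot tell which of the two matters. Compound 3 shares the methyl groups with compound 1 but carries two of them, as compound 2 carries two chlorines. The expectation is therefore a step down from compound 2, a number 25 percentage points lower from compound 2 to compound 3 (beyond the scatter), with wide uncertainty. Compound 3 is estimated at 20%, in the range 4% to 50%.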

Compound 3, a percentage reported as activity, at one concentration (the size of the read-out at that concentration, not a potency): 20%
For compound 3 middle estimate and measured number coincide at the digits printed, within the range that was stated.
By their numbers in this assay, from the lowest: compound 1; then compound 3; then compound 2.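

Two single changes now separate what the earlier step from compound 1 to compound 2 had mixed together. With the two substituted places on the pendant ring held the same, a number 25 percentage points lower from compound 2 to compound 3 (beyond the scatter) in this assay shows that the kind of group matters, even though 3,4-dichlorophenyl and 3,4-dimethylphenyl have the same count of heavy atoms; and a number 14.6 percentage points higher from compound 1 to compound 3 (beyond the scatter) shows that the number of groups matters too, since adding one methyl in place of hydrogen on an aromatic carbon, with the kind of group unchanged, also weakens the effect. The large earlier jump is therefore not the work of one change alone, but these numbers offer nothing that explains why either change acts as it does.

As far as these compounds go, what remains open is how a single chlorine, as in 4-chlorophenyl, or a 3-methylphenyl ring would read, which would show whether each of the two places on the ring contributes on its own. Also open, from the compounds shown here alone, is whether a different group at these places, such as methoxy or an amine, would keep the stronger effect of compound 1 or lose it.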